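Swapping a Hydrazide for an Ester on a Shared Core

This account rests on a few compounds, and the source may have more. Where it says the series, first, only, none or still open, it means among the compounds named here.

Compound 1 `COc1cccc(-c2nc(SC)nc3sc(C(=O)NCC#N)c(N)c23)c1` gives 20.3% in a functional assay on HEK293 cells for agonist activity at lutropin-choriogonadotropic hormone receptor (Homo sapiens), read by cAMP accumulation; on this read-out lower numbers stand for smaller maximal responses and higher numbers for larger maximal responses.
Compound 2 `COc1cccc(-c2nc(SC)nc3sc(C(=O)NCCO)c(N)c23)c1` gives 20.5% in this assay.
Compound 3 `COc1cccc(-c2nc(SC)nc3sc(C(=O)NNC(=O)OC(C)(C)C)c(N)c23)c1` gives 2.4% in this assay.

Compound 3 stands lowest of the three, and its gap to both others is beyond the scatter. The two steps that lead to it are alike in size: a number 17.9 percentage points lower from compound 1 to compound 3 (beyond the scatter) and a number 18.1 percentage points lower from compound 2 to compound 3 (beyond the scatter), both modest drops, while a number 0.2 percentage points higher from compound 1 to compound 2 (within the scatter) shows that the two smaller amide chains behave the same within the scatter.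

Compound 4 `COc1cccc(-c2nc(SC)nc3sc(C(=O)OC(C)(C)C)c(N)c23)c1` has not been measured. It differs from compound 3 in one place: tert-butoxy in place of ((tert-butoxycarbonyl)amino)amino on a carbonyl carbon. This removes the hydrazide amide entirely and leaves an ester on the carbonyl carbon. Among the compounds with values here, no measured step covers an ester, so the closest guide is the pair of drops into compound 3, which suggest that the large hydrazide attachment is what pulls the response down. Removing it is therefore expected to lift the response partway back toward compounds 1 and 2, though with wide uncertainty.

Compound 4 is expected to give 12% in this assay, within 0% to 35%, which corresponds to an expected step of a number 9.6 percentage points higher from compound 3 to compound 4 (within the scatter).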

Compound 4, largest response reached (reported as efficacy), in percent of the reference or control that the assay uses: 23.8%
Compound 4: middle estimate off by 11.8 percentage points, on the low side; low and high end bracket the measured number.
By their numbers in this assay, from the lowest: compound 3; then compounds 1, 2 and 4 (each within the scatter of the next).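

In this assay, the step of a number 21.4 percentage points higher from compound 3 to compound 4 (beyond the scatter) shows that the low response is not fixed by the shared core: with tert-butoxy in place of ((tert-butoxycarbonyl)amino)amino on the carbonyl carbon, the response returns to the level of the two amides. The steps of a number 3.3 percentage points higher from compound 2 to compound 4 (within the scatter) and a number 3.5 percentage points higher from compound 1 to compound 4 (within the scatter) both lie within the scatter, so an ester and these two amides cannot be told apart here, and a nitrogen on this carbonyl carbon is not needed for this level of response among these compounds. Nothing available here explains why the hydrazide differs from the other three.

The compounds shown leave open whether the low response goes with the hydrazide nitrogens themselves or with the tert-butoxycarbonyl group they carry, a question that a plain hydrazide ending in a free amine could help to settle. Also open, from the compounds shown here alone, is how far this position tolerates other groups on the same carbonyl carbon, such as the small methyl ester or the carboxylic acid, which would show whether the tert-butyl part of the ester matters at all.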